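The compounds below may be only part of what the source reports. "The series", "measured", "known", "first", "only" and "open" are said of these compounds alone.

Measured compounds:
compound 1, `Nc1oncc1-c1ccccc1`, 85 nM
compound 2, `Nc1oncc1-c1cccc(Cl)c1`, 250 nM

For the measured compounds named here, in an assay on SW48 cells for inhibition of Tryptophan 2,3-dioxygenase (Homo sapiens), read by fluorescence, with a stated time of 30 min (on this read-out lower numbers stand for an effect already at smaller amounts and higher numbers for an effect only at larger amounts of compound), compound 2 gives 250 nM, the higher of the two numbers so far, while compound 1 gives 85 nM. Going by the values given here, the only measured step, a 2.9-fold higher number from compound 1 to compound 2 (0.47 log units; beyond the scatter), shows that adding a chloro at this place raised the number, meaning that more compound was needed for the same effect.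

Compound 3, `COc1cccc(-c2cnoc2N)c1`, differs from compound 2 by methoxy in place of chloro on an aromatic carbon, meta to a group of 6 heavy atoms. Among the compounds with values here, no measured pair compares methoxy with chloro directly, so the bearing of the chloro step is indirect: compound 1, which carries neither group, stands lower than compound 2. The methoxy may give back part of that difference, or none of it. The expected step in this assay is therefore small, a 1.3-fold lower number from compound 2 to compound 3 (0.10 log units; within the scatter), within the usual scatter, leaning slightly lower. Compound 3 is estimated at 200 nM, with a range from 70 nM to 600 nM.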

Compound 3, half-maximal effective concentration: 1500 nM
For compound 3 the middle estimate is 7.5-fold (0.88 log units) below the measured one; the measured number lies above the stated range.
By their numbers in this assay, from the lowest: compound 1; then compound 2; then compound 3.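

In this assay exchanging chloro for methoxy on this aromatic carbon gives a 6.0-fold higher number from compound 2 to compound 3 (0.78 log units; beyond the scatter) so the two groups are far from interchangeable at this place. Set against plain hydrogen, methoxy gives an 18-fold higher number from compound 1 to compound 3 (1.25 log units; beyond the scatter) and this large step goes the same way as the modest one for chloro, a 2.9-fold higher number from compound 1 to compound 2 (0.47 log units; beyond the scatter) so both groups raise the number, but by clearly different amounts. The data offered here include no measurement that accounts for the gap between these two groups.

From the compounds shown here alone, it remains open whether any group on this carbon, such as fluoro, an amine or a carboxylic acid, could bring the number below that of compound 1. Going by these compounds, it is also open whether chloro and methoxy would rank the same way on other carbons of the ring.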